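Rearranging one ring: from compound 3 to compound 4

A few compounds are considered here, and "the series" means these few. Any claim that something is new, unique, unknown or untested is made for them only; others in the source may bear on it.

Measured so far in a physicochemical assay for lipophilicity, read by HPLC, measured as chromatographic lipophilicity, at pH 7.4; on this read-out higher numbers stand for higher lipophilicity and lower numbers for lower lipophilicity:

- compound 1 `N#Cc1cnc(N2CCC(C(=O)N3N=CC[C@H]3c3cc(F)cc(F)c3)CC2)cn1` gives 5.2
- compound 2 `Cc1nnc(N2CCC(C(=O)N3N=CC[C@H]3c3cc(F)cc(F)c3)CC2)o1` gives 3.6
- compound 3 `N#Cc1nccc(N2CCC(C(=O)N3N=CC[C@H]3c3cc(F)cc(F)c3)CC2)n1` gives 5.1

These three compounds share a core and differ only in the group on an amine nitrogen in a ring. Compound 3 sits level with compound 1, as the step of a number 0.10 log units lower from compound 1 to compound 3 (within the scatter) shows. Compound 2 lies well away from that pair, with a number 1.50 log units higher from compound 2 to compound 3 (beyond the scatter) as the measure of the gap.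

The next compound, compound 4 `N#Cc1cc(N2CCC(C(=O)N3N=CC[C@H]3c3cc(F)cc(F)c3)CC2)ncn1`, has the same atoms as compound 3, joined differently. Its 2-cyanopyrimidin-4-yl gives way to a group with no common name a group of 8 heavy atoms (5 carbon, 3 nitrogen; one six-membered aromatic ring with 2 hetero atoms) in place of a group of 8 heavy atoms (5 carbon, 3 nitrogen; one six-membered aromatic ring with 2 hetero atoms), on an amine nitrogen in a ring on the same amine nitrogen.

The most relevant measured step is a number 0.10 log units lower from compound 1 to compound 3 (within the scatter), since it also swaps one group of this kind for another. For the measured compounds named here, it is only a single example. The large steps, a number 1.60 log units lower from compound 1 to compound 2 (beyond the scatter) and a number 1.50 log units higher from compound 2 to compound 3 (beyond the scatter), both involve the 5-methyl-1,3,4-oxadiazol-2-yl of compound 2, a different kind of group, and bear little on this change. No shift beyond the scatter is therefore expected in this assay. The expected result is no change at the digits printed from compound 3 to compound 4 (within the scatter). For compound 4 the estimated value is 5.1, with an expected range from 4.7 to 5.5.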

Compound 4, distribution coefficient: 5
Estimate against measurement, compound 4: 0.10 log units above, and the stated range covers the measured number.
By their numbers in this assay, from the lowest: compound 2; then compounds 4, 3 and 1 (each within the scatter of the next).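

In this assay the rearrangement on this amine nitrogen in a ring amounts to a number 0.10 log units lower from compound 3 to compound 4 (within the scatter) and sits alongside a number 0.20 log units lower from compound 1 to compound 4 (within the scatter) in showing no separation among the three cyano-bearing six-membered aromatic rings. Compound 1, compound 3 and compound 4 carry groups with the same heavy atoms joined in three different ways, so in this short series the read-out does not tell these arrangements apart. The gap to the five-membered ring of compound 2 stays as wide with the new arrangement, as a number 1.40 log units higher from compound 2 to compound 4 (beyond the scatter) shows, and compound 2 therefore remains the only one of the four that stands apart from the others.

No measurement offered here accounts for why the three arrangements read alike. From the compounds shown here alone, it remains open whether this level reading would hold with a methyl, an amine or a carboxylic acid in place of the nitrile on the same six-membered ring, and whether the large step to compound 2 belongs to its five-membered ring or to its methyl in place of a nitrile.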